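A few compounds are considered here, and "the series" means these few. Any claim that something is new, unique, unknown or untested is made for them only; others in the source may bear on it.

Of the compounds shown here, three that share the same core have been tested in an assay on liver (Sus scrofa) for inhibition of glucose-6-phosphatase catalytic subunit 1 (Homo sapiens), using microsomes; on this read-out lower numbers stand for stronger inhibition and higher numbers for weaker inhibition. Compound 1 `C/C(=N\N(Cc1ccccc1)Cc1ccccc1)c1ccccc1` gives 25000 nM in this assay, and compound 2 `c1ccc(CN(Cc2ccccc2)/N=C2\CCCc3ccccc32)cc1` gives 25000 nM. Compound 3 `Oc1ccc(/C=N/N(Cc2ccccc2)Cc2ccccc2)cc1` gives 2400 nM, the lowest number of the three, and its gap to compound 1 and to compound 2 lies beyond the usual scatter, so compound 3 is the strongest inhibitor measured so far.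

Compound 4 `Clc1ccc(/C=N/N(Cc2ccccc2)Cc2ccccc2)s1` differs from compound 3 in one place: 5-chlorothiophen-2-yl in place of 4-hydroxyphenyl on a carbon with a double bond to nitrogen. Among the measured compounds shown here, no measured pair shows this kind of change, so its effect cannot be read from the data. For the measured compounds named here, the two groups are of similar size as counted, but the single hydrogen-bond donor of compound 3 leaves with the 4-hydroxyphenyl group. The step from compound 3 to compound 4 is expected to be a 2.5-fold higher number from compound 3 to compound 4 (0.40 log units; beyond the scatter), a modest weakening. Compound 4 is therefore estimated to give about 6000 nM in this assay, within a range from 1500 nM to 25000 nM.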

Compound 4, half-maximal inhibitory concentration: 170 nM
Estimate against measurement, compound 4: 35-fold (1.55 log units) above, and the stated range ends above it.
By their numbers in this assay, from the lowest: compound 4; then compound 3; then compounds 1 and 2 (each within the scatter of the next).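

Among the compounds shown here, this is the first time the group on a carbon with a double bond to nitrogen has been exchanged on its own, and in this assay the exchange gives a 14-fold lower number from compound 3 to compound 4 (1.15 log units; beyond the scatter), so what sits at this position can shift the number strongly. A hydrogen-bond donor in this group is not required for a low number: 5-chlorothiophen-2-yl has 0 hydrogen-bond donors, and compound 4 gives the lowest number of the four. No evidence at hand explains the size of this step.

The ring, the chlorine and the hydroxyl all change in this single step, so the compounds shown cannot tell which of them matters most. A 4-chlorophenyl group or a plain thiophen-2-yl group in this place would help to separate these contributions.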